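This account rests on a few compounds, and the source may have more. Where it says the series, first, only, none or still open, it means among the compounds named here.

Among the compounds with values here, compound 2 `CCNC(=O)N1CCN(C(=S)SCc2cn(Cc3ccccc3F)nn2)CC1` is the only compound of the pair with a number in a functional assay on MCF7 cells (Homo sapiens) for cytotoxicity, read by MTT assay, with a stated time of 72 h (on this read-out higher numbers stand for weaker inhibition and lower numbers for stronger inhibition), where compound 2 gives 5760 nM. Compound 1 `NC(=O)N1CCN(C(=S)SCc2cn(Cc3ccccc3F)nn2)CC1` reports only a limit in this assay: compound 1 gives > 128000 nM. Compound 3 `CC(C)NC(=O)N1CCN(C(=S)SCc2cn(Cc3ccccc3F)nn2)CC1` differs from compound 2 by methyl in place of hydrogen on a saturated chain carbon bound to an amide-type nitrogen and a saturated chain carbon. Within the data shown here, the single measured step, an at least 22-fold lower number from compound 1 to compound 2 (1.34 log units; beyond the scatter), bears on this change, but that step put an alkyl where none stood, whereas here an existing ethyl grows to isopropyl. Compound 3 is therefore expected to shift only a 1.3-fold lower number from compound 2 to compound 3 (0.11 log units; within the scatter), within the scatter. Compound 3 is estimated at 4500 nM, between 1500 nM and 14000 nM.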

Compound 3, half-maximal inhibitory concentration: 1860 nM
Beside the measured number, compound 3's estimate is 2.4-fold (0.38 log units) above it, within the range that was stated.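

In this assay, the position on the amide-type nitrogen still responds once an alkyl group is present: growing ethyl to isopropyl gives a 3.1-fold lower number from compound 2 to compound 3 (0.49 log units; beyond the scatter). Taken whole, isopropyl in place of hydrogen on that nitrogen gives an at least 68-fold lower number from compound 1 to compound 3 (1.83 log units; beyond the scatter). Compound 1 is held only at a limit, so this larger step is a bound and not a measured size: the limit of > 128000 nM in this assay, at which 1 of the 3 values shown sits.

On these data alone, whether a longer chain such as n-propyl, or a tert-butyl or cyclopropyl group, would continue this change remains open. So does whether a straight chain and a branched one of equal size would read alike.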